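Urea series: chloro added to the trifluoromethylphenyl ring

A few compounds are considered here, and "the series" means these few. Any claim that something is new, unique, unknown or untested is made for them only; others in the source may bear on it.

Compound 1 `COc1cc(-c2nn(-c3cccc(NC(=O)c4cccc(C(F)(F)F)c4)c3)cc2-c2ccncc2)ccc1Cl` and compound 2 `COc1cc(-c2nn(-c3cccc(NC(=O)Nc4cccc(C(F)(F)F)c4)c3)cc2-c2ccncc2)ccc1Cl` share one core and differ only at the carbonyl carbon. In a functional assay on Malme-3M cells (Homo sapiens) for inhibition, read by sulforhodamine B assay, with a stated time of 48 h (on this read-out higher numbers stand for weaker inhibition of growth and lower numbers for stronger inhibition of growth), compound 1 gives 1990 nM, and compound 2 gives 1050 nM. Within the data shown here, the single measured step is a 1.9-fold lower number from compound 1 to compound 2 (0.28 log units; within the scatter). Among the measured compounds shown here, compound 2 thus holds the lowest of the two numbers in this assay, with compound 1 as its only neighbour; the two lie within the scatter of each other, so no order between them is claimed.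

Compound 3 `COc1cc(-c2nn(-c3cccc(NC(=O)Nc4ccc(Cl)c(C(F)(F)F)c4)c3)cc2-c2ccncc2)ccc1Cl` differs from compound 2 by chloro in place of hydrogen on an aromatic carbon. For the measured compounds named here, no measured step bears directly on this change: the step from compound 1 to compound 2 concerns the group on the carbonyl carbon, not the trifluoromethylphenyl ring, and it stayed within the scatter. The data give no ground for a direction, and an addition of one chlorine is a small change. In this assay the expected step is a 1.2-fold lower number from compound 2 to compound 3 (0.09 log units; within the scatter), not beyond the scatter. Compound 3 is therefore expected to give about 850 nM in this assay, within a range of 300 nM to 2500 nM.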

Compound 3, concentration for 50% growth inhibition: 838 nM
Beside the measured number, compound 3's estimate is 1.0-fold (0.01 log units) above it; the measured number falls inside the stated range.
By their numbers in this assay, from the lowest: compounds 3, 2 and 1 (each within the scatter of the next, the first and the last beyond it).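

In this assay, chloro in place of hydrogen, ortho to the trifluoromethyl group and para to a large group, gives a 1.3-fold lower number from compound 2 to compound 3 (0.10 log units; within the scatter), so compound 2 and compound 3 cannot be ordered and this aromatic carbon accepts a chlorine with no resolved effect on the read-out. Among these compounds, the combined replacement on the carbonyl carbon, (4-chloro-3-(trifluoromethyl)phenyl)amino in place of 3-(trifluoromethyl)phenyl, gives a 2.4-fold lower number from compound 1 to compound 3 (0.38 log units; beyond the scatter), the only step so far to clear the scatter, although the amino change alone gives a 1.9-fold lower number from compound 1 to compound 2 (0.28 log units; within the scatter) and the chloro change alone also stays within it. Nothing available explains this modest combined step.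

Open, from the compounds shown here alone, is whether a fluorine, a methoxy group or an amine on the same aromatic carbon would give a step beyond the scatter from compound 2. Also open, going by these compounds, is whether chloro at this carbon would give a comparable step without the amino group, with the 3-(trifluoromethyl)phenyl attached directly to the carbonyl carbon as in compound 1.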